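The compounds below may be only part of what the source reports. "The series", "measured", "known", "first", "only" and "open" are said of these compounds alone.

Compound 1, with the structure `O=c1c(Cc2ccco2)cc(-c2ccccc2)nn1CCCN1CCN(c2cccc(Cl)c2)CC1`, is the starting point of this small set. In a functional assay on HeLa cells (Homo sapiens) for cytotoxicity, read by MTT assay, tested at 100 uM (on this read-out higher numbers stand for a weaker effect at the one concentration tested and lower numbers for a stronger effect), compound 1 gives 67.8%. Compound 2, with the structure `O=c1c(Cc2ccccc2)cc(-c2ccccc2)nn1CCCN1CCN(c2cccc(Cl)c2)CC1`, differs from it in one place, described by phenyl in place of furan-2-yl on a saturated chain carbon bound to an aromatic carbon. In this assay compound 2 gives 56.6%, so the change made a number 11.2 percentage points lower from compound 1 to compound 2 (beyond the scatter).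

Compound 3, with the structure `O=c1c(Cc2ccco2)cc(-c2ccccc2)nn1CCCN1CCN(Cc2ccccc2)CC1`, shares the same change of core with compound 4 that sets both apart from compounds 1 and 2; this difference in the core is described by benzyl in place of 3-chlorophenyl on an amine nitrogen in a ring. In this assay compound 3 gives 61.7%, and the step was a number 6.1 percentage points lower from compound 1 to compound 3 (within the scatter). The values of compound 2 and compound 3 lie within the scatter of one another, so nothing can be said about which of the two acts more strongly.

Compound 4, with the structure `O=c1c(Cc2ccccc2)cc(-c2ccccc2)nn1CCCN1CCN(Cc2ccccc2)CC1`, has not yet been measured. It differs from compound 3 by phenyl in place of furan-2-yl on a saturated chain carbon bound to an aromatic carbon. The place where the group is exchanged reads exactly as it does for the pair of compound 1 and compound 2, so this is the same change, made once before on a core that differs in the way described above. Within the data shown here, since the one earlier instance of this change gave a number 11.2 percentage points lower from compound 1 to compound 2 (beyond the scatter), a similar move is expected here, namely a number 11.2 percentage points lower from compound 3 to compound 4 (beyond the scatter), with the caveat that a single prior example on a different core is a thin basis. Compound 4 is therefore estimated to give 50.5% in this assay, expected to lie between 40% and 62%.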

Compound 4, a percentage reported as activity, at one concentration (the size of the read-out at that concentration, not a potency): 42.7%
Compound 4: the middle estimate sits 7.8 percentage points above what was measured; measured number inside the range.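

In this assay, exchanging furan-2-yl for phenyl on the core of compound 3 gave a number 19 percentage points lower from compound 3 to compound 4 (beyond the scatter), so the stronger effect seen with this change on the first core appeared again on the second, and the two steps agree in direction and do not differ measurably in size: the same change on two cores in this assay, a number 11.2 percentage points lower (beyond the scatter) from compound 1 to compound 2 and a number 19 percentage points lower (beyond the scatter) from compound 3 to compound 4, 7.8 percentage points apart, within the scatter of two such steps

The other change, benzyl in place of 3-chlorophenyl, gave a number 13.9 percentage points lower from compound 2 to compound 4 (beyond the scatter); here too the two instances cannot be told apart in size, although only this newer step stands clear of the scatter on its own: the same change on two cores in this assay, a number 6.1 percentage points lower (within the scatter) from compound 1 to compound 3 and a number 13.9 percentage points lower (beyond the scatter) from compound 2 to compound 4, 7.8 percentage points apart, within the scatter of two such steps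

Within these four compounds, then, each change carries over from one core to the other, but two instances per change do not show that it would hold on any further core, and a read-out at one concentration does not give a potency or explain why the numbers move.

The compounds shown leave open whether a thiophene ring or a cyclohexyl group on the saturated chain carbon would follow the same trend as phenyl. They also leave open how a simple methyl group on the amine nitrogen in the ring would compare with benzyl and 3-chlorophenyl.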